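The source may report more compounds than this note shows. Statements on the series, on what has been measured and on what is new or still open speak of the compounds shown alone.

Working notes on the series. The common scaffold carries an acetyl-linked azole on the piperazine nitrogen; the measured variation is in that azole. Compound 1 `C[C@@H]1CN(c2sc(C(F)(F)F)nc2-c2nc3ccccc3[nH]2)CCN1C(=O)Cn1cccn1` gives 191 nM in a functional assay on Venous blood for antagonist activity at C-X-C chemokine receptor type 3 (Homo sapiens), read by flow cytometry, with a stated time of 30 min, in the presence of a further agent that is not named here; on this read-out higher numbers stand for weaker inhibition and lower numbers for stronger inhibition. Compound 2 `C[C@@H]1CN(c2sc(C(F)(F)F)nc2-c2nc3ccccc3[nH]2)CCN1C(=O)CN1CCC(F)(F)CC1` gives 2430 nM. Compound 3 `C[C@@H]1CN(c2sc(C(F)(F)F)nc2-c2nc3ccccc3[nH]2)CCN1C(=O)Cn1cc(Cl)cn1` gives 251 nM, the second highest of the three numbers, sitting close to compound 1 and well apart from compound 2.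

The next compound, compound 4 `Cc1nc(C)n(CC(=O)N2CCN(c3sc(C(F)(F)F)nc3-c3nc4ccccc4[nH]3)C[C@H]2C)n1`, differs from compound 3 by 3,5-dimethyl-1H-1,2,4-triazol-1-yl in place of 4-chloro-1H-pyrazol-1-yl on a saturated chain carbon bound to a carbonyl carbon. For the measured compounds named here, two measured steps bear on this. The exchange of the aromatic pyrazole for a saturated ring gave a 9.7-fold lower number from compound 2 to compound 3 (0.99 log units; beyond the scatter) and, read the other way, a 13-fold higher number from compound 1 to compound 2 (1.10 log units; beyond the scatter); the small substitution on the pyrazole gave a 1.3-fold higher number from compound 1 to compound 3 (0.12 log units; within the scatter). Compound 4 keeps a five-membered aromatic ring bound through nitrogen, so the step should resemble the small one rather than the large one, with some added uncertainty because the ring type and the two methyls are new to the set.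

Compound 4 is therefore expected to change by about a 1.4-fold higher number from compound 3 to compound 4 (0.14 log units; within the scatter) in this assay, with no firm direction. The estimate for compound 4 is 350 nM, within a range of 130 nM to 950 nM.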

Compound 4, half-maximal inhibitory concentration: 237 nM
Estimate against measurement, compound 4: 1.5-fold (0.17 log units) above; the range from low to high includes it.
By their numbers in this assay, from the lowest: compounds 1, 4 and 3 (each within the scatter of the next); then compound 2.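

In this assay, the 3,5-dimethyl-1H-1,2,4-triazol-1-yl group on a saturated chain carbon bound to a carbonyl carbon gives a 1.1-fold lower number from compound 3 to compound 4 (0.02 log units; within the scatter) and a 1.2-fold higher number from compound 1 to compound 4 (0.09 log units; within the scatter), so compound 4 cannot be told apart from either pyrazole, even with a third ring hetero atom and two methyl groups present. The contrast with the saturated ring now holds for three aromatic groups rather than two, with a 10-fold lower number from compound 2 to compound 4 (1.01 log units; beyond the scatter): compounds 1, 3 and 4 all carry a five-membered aromatic ring and sit together, while compound 2, with its 4,4-difluoropiperidin-1-yl group, stands apart. No supporting measurement accompanies these numbers, so the reason for this grouping remains unknown.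

The compounds shown do not separate the effect of the saturated ring itself from that of its two fluorines, a question that piperidin-1-yl or morpholin-4-yl at this position would address. Going by these compounds, it also remains open whether the grouping extends to a phenyl ring, to an azole bound through carbon, or to a longer chain between the carbonyl and the ring.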